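The compounds below may be only part of what the source reports. "The series", "measured", "known", "first", "only" and "open" are said of these compounds alone.

Compound 2, `C[C@H]1CCCC[C@H](CCCC(Cl)Cl)c2c(O)cc(cc2O)[C@H](O)[C@@H](C)CCCC[C@H](CCCC(Cl)Cl)c2c(O)cc(cc2O)C1`, and compound 1, `CCCC[C@H]1CCCC[C@H](C)[C@@H](O)c2cc(O)c(c(O)c2)[C@@H](CCCC(Cl)Cl)CCCC[C@H](C)[C@@H](O)c2cc(O)c1c(O)c2`, are the two compounds measured here. In a functional assay on HT-29 cells (Homo sapiens) for cytotoxicity (on this read-out lower numbers stand for an effect already at smaller amounts and higher numbers for an effect only at larger amounts of compound), compound 2 gives 2800 nM, the highest of the two numbers, while compound 1 gives 1700 nM; the two values lie within the scatter of each other, so no order can be read from them. Compound 3, `CCCC[C@H]1CCCC[C@H](C)Cc2cc(O)c(c(O)c2)[C@@H](CCCC(Cl)Cl)CCCC[C@H](C)[C@@H](O)c2cc(O)c1c(O)c2`, has not yet been measured. It differs from compound 2 in one place: methyl in place of dichloromethyl on a saturated chain carbon, three bonds along the chain from a saturated ring carbon. Among the compounds with values here, with no measured pair that shows this change on its own, the size of its effect cannot be taken from data; the two values seen so far suggest the shared core tolerates such changes without a large shift in this assay. The step from compound 2 to compound 3 is therefore expected to be small, a 1.3-fold lower number from compound 2 to compound 3 (0.10 log units; within the scatter), within the scatter. Compound 3 is estimated to give 2200 nM, with a range from 1000 nM to 5000 nM.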

Compound 3, half-maximal effective concentration: 900 nM
The estimate for compound 3 lay 2.4-fold (0.39 log units) above the measured number; the whole stated range lies above it.
By their numbers in this assay, from the lowest: compounds 3, 1 and 2 (each within the scatter of the next, the first and the last beyond it).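

In this assay, methyl in place of dichloromethyl on a saturated chain carbon, three bonds along the chain from a saturated ring carbon, gives a 3.1-fold lower number from compound 2 to compound 3 (0.49 log units; beyond the scatter) and so shows that this position is not indifferent to change, which the two earlier values could not show. Hydrogen in place of hydroxy on a saturated ring carbon gives a 1.9-fold lower number from compound 1 to compound 3 (0.28 log units; within the scatter) and so shows no clear role for that hydroxy in this read-out. Nothing at hand explains either step.

From the compounds shown here alone, it remains open whether an amine, a carboxylic acid or a longer chain at the same chain position would shift the number in the same direction as methyl. Also open, going by these compounds, is whether replacing the remaining dichloromethyl group of compound 3 with methyl would produce a similar step.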